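A few compounds are considered here, and "the series" means these few. Any claim that something is new, unique, unknown or untested is made for them only; others in the source may bear on it.

Measured so far:
compound 1 `COC(=O)CC1c2ccccc2N=C(N2CCN(C)CC2)N1c1ccccc1`, giving 15% in a functional assay on cells (Oocyte) for inhibition of Voltage-dependent T-type calcium channel subunit alpha-1H (Homo sapiens), tested at 100 uM; on this read-out higher numbers stand for more inhibition at the one concentration tested (going by the name of the read-out) and lower numbers for less inhibition
compound 2 `O=C(CC1c2ccccc2N=C(c2ccccc2)N1c1ccccc1)NCc1ccccc1`, giving 14.8%
compound 3 `O=C(CC1c2ccccc2N=C(c2ccccc2)N1c1ccccc1)OCc1ccccc1`, giving 14.2%

Compound 3 has the lowest of the three numbers, but its gaps to compound 2 and to compound 1 are both within the scatter, so the three stand together. Within the data shown here, the one measured step, a number 0.6 percentage points lower from compound 2 to compound 3 (within the scatter), is within the scatter. Compound 4 `CN1CCN(C2=Nc3ccccc3C(CC(=O)OCc3ccccc3)N2c2ccccc2)CC1` differs from compound 3 by 4-methylpiperazin-1-yl in place of phenyl on a carbon with a double bond to nitrogen. Among the measured compounds shown here, no measured step covers this change; compound 1 carries the same entering group on a different ester and its value sits with the others. Compound 4 is therefore expected to stay in the same band, with a number 0.8 percentage points higher from compound 3 to compound 4 (within the scatter) as the estimated step. The estimate for compound 4 is 15%, between 5% and 26%.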

Compound 4, a percentage reported as inhibition, at one concentration (the size of the read-out at that concentration, not a potency): 32.7%
Estimate against measurement, compound 4: 17.7 percentage points below, and the stated range ends below it.
By their numbers in this assay, from the lowest: compounds 3, 2 and 1 (each within the scatter of the next); then compound 4.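

In this assay, among these compounds, 4-methylpiperazin-1-yl in place of phenyl on the carbon with a double bond to nitrogen gives a number 18.5 percentage points higher from compound 3 to compound 4 (beyond the scatter) and is the first change to clear the scatter. With that group present, the ester also counts: phenyl in place of hydrogen on the chain carbon bound to the ester oxygen gives a number 17.7 percentage points higher from compound 1 to compound 4 (beyond the scatter) for the benzyl over the methyl ester. Nothing available explains either step. Open, on these data alone, is whether an unsubstituted piperazine or a morpholine on this carbon holds the higher number. Also open, as far as these compounds go, is whether the benzylamide of compound 2 does so alongside 4-methylpiperazin-1-yl.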